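The compounds below may be only part of what the source reports. "The series", "measured", "known", "first", "only" and "open" are said of these compounds alone.

Measured compounds:
compound 1, `CCN(CCn1ccc(-c2ccc(C(F)(F)F)cn2)n1)C(=O)c1cc(C)ccc1-n1nccn1`, in a functional assay on CHO cells for antagonist activity at Orexin/Hypocretin receptor type 1 (Homo sapiens), read by fluorescence and calcium flux, with a stated time of 30 min (a higher number here means a weaker inhibitor, a lower number a stronger inhibitor), gives 48.6 nM;
compound 2, `CCN(CCn1ccc(-c2cc(C(F)(F)F)ccn2)n1)C(=O)c1cc(C)ccc1-n1nccn1`, in this assay gives 28 nM.

Compound 2 stands at the lowest of the two numbers shown, yet the step of a 1.7-fold lower number from compound 1 to compound 2 (0.24 log units; within the scatter) is within the scatter, so nothing firmly separates the two compounds. Compound 3, `CCN(CCn1ccc(-c2cccc(C(F)(F)F)n2)n1)C(=O)c1cc(C)ccc1-n1nccn1`, has not been measured. It differs from compound 2 by 6-(trifluoromethyl)pyridin-2-yl in place of 4-(trifluoromethyl)pyridin-2-yl on an aromatic carbon: the trifluoromethyl group stays on the same six-membered aromatic ring but sits at another position. For the measured compounds named here, the one measured step that bears on this is a 1.7-fold lower number from compound 1 to compound 2 (0.24 log units; within the scatter), also a move of the trifluoromethyl group on that ring, which changed the number only a little. With a single comparison, and a different position this time, the expected step is a 2.1-fold higher number from compound 2 to compound 3 (0.33 log units; beyond the scatter), a slight weakening that may well stay inside the scatter. Compound 3 is therefore estimated at 60 nM, with a range from 20 nM to 200 nM.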

Compound 3, antagonist equilibrium constant: 3.19 nM
For compound 3 the middle estimate is 19-fold (1.27 log units) above the measured one; measured number outside the range, below it.
By their numbers in this assay, from the lowest: compound 3; then compounds 2 and 1 (each within the scatter of the next).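

In this assay, the 6-(trifluoromethyl)pyridin-2-yl group sets compound 3 clearly apart from both of its isomers, with an 8.8-fold lower number from compound 2 to compound 3 (0.94 log units; beyond the scatter) and a 15-fold lower number from compound 1 to compound 3 (1.18 log units; beyond the scatter). The earlier pair, 4-(trifluoromethyl)pyridin-2-yl and 5-(trifluoromethyl)pyridin-2-yl, could not be separated, so moving the trifluoromethyl group around this ring looked like a minor change; compound 3 shows that, with the same atoms joined differently, one placement can matter a great deal. Nothing given here accounts for why this placement stands apart from the other two.

Going by these compounds, it remains open whether the trifluoromethyl group itself is needed, or whether a methyl group or a chlorine atom in its place on the 6-substituted ring would give a similar number. On these data alone, it is also open whether a plain phenyl ring could replace the pyridin-2-yl ring.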